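Growing the Nitrogen Substituent: Ethyl to Isopropyl on Compound 3

The compounds below may be only part of what the source reports. "The series", "measured", "known", "first", "only" and "open" are said of these compounds alone.

Of the compounds shown here, three sharing one core have been measured in an assay on HEK293 cells for inhibition of acid ceramidase (Homo sapiens), read by fluorescence, with stated times of 10 min and 3 h; on this read-out higher numbers stand for weaker inhibition and lower numbers for stronger inhibition. Compound 1 `CN1CCN(c2ccc3c(c2)oc(=O)n3C(=O)NCCCCc2ccccc2)CC1=O` gives 92 nM. Compound 2 `CN1CCC(c2ccc3c(c2)oc(=O)n3C(=O)NCCCCc2ccccc2)CC1=O` gives 105 nM. Compound 3 `CCN1CCC(c2ccc3c(c2)oc(=O)n3C(=O)NCCCCc2ccccc2)CC1` gives 92 nM. The three differ only in the saturated ring attached to the aromatic carbon, and none of the steps between them reaches beyond the scatter: a 1.1-fold higher number from compound 1 to compound 2 (0.06 log units; within the scatter), no change at the digits printed from compound 1 to compound 3 (within the scatter), and a 1.1-fold lower number from compound 2 to compound 3 (0.06 log units; within the scatter). On these numbers compound 3 stands level with compound 1 at the digits printed, and the two together give the lowest numbers of the three, though the gap to compound 2 is also within the scatter.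

Compound 4 `CC(C)N1CCC(c2ccc3c(c2)oc(=O)n3C(=O)NCCCCc2ccccc2)CC1` has not yet been measured. It differs from compound 3 by methyl in place of hydrogen on a saturated chain carbon bound to an amine nitrogen in a ring and a saturated chain carbon. Among the measured compounds shown here, no measured step touches the group on the ring nitrogen: the steps that do exist swap one saturated ring for another and all stay within the scatter. The closest guidance is that the ring changes from compound 1 through compound 3 left the number essentially unmoved, so a small enlargement of the nitrogen substituent is expected to do likewise, giving an expected 1.0-fold higher number from compound 3 to compound 4 (0.01 log units; within the scatter). Compound 4 is therefore estimated at 95 nM, with a range from 45 nM to 200 nM.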

Compound 4, half-maximal inhibitory concentration: 94 nM
Compound 4: middle estimate off by 1.0-fold (0.00 log units), on the high side, within the range that was stated.
By their numbers in this assay, from the lowest: compounds 1, 3, 4 and 2 (each within the scatter of the next).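

This is the first change shown that touches the group on the ring nitrogen itself: in this assay, going from ethyl to isopropyl adds one methyl on a saturated chain carbon bound to an amine nitrogen in a ring, and the result is a 1.0-fold higher number from compound 3 to compound 4 (0.01 log units; within the scatter) and so stays within the scatter. Among the compounds shown here, the earlier compounds showed only that one saturated ring could replace another, whereas this step shows that the substituent on the ring nitrogen can grow by one carbon, from a straight chain to a branched one, with no measurable effect on the number. The 1-isopropylpiperidin-4-yl group also stays level with the other two ring groups, with a 1.1-fold lower number from compound 2 to compound 4 (0.05 log units; within the scatter) and a 1.0-fold higher number from compound 1 to compound 4 (0.01 log units; within the scatter), and nothing at hand explains why the number holds steady at this position.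

On these data alone, how far this tolerance extends remains open, since a bare hydrogen on the ring nitrogen, a tert-butyl group, a cyclopropylmethyl group or a benzyl group could each behave differently from ethyl and isopropyl. As far as these compounds go, it is also open whether an acetyl group on that nitrogen, which would place a carbonyl directly on it, would keep the number level.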